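Fluoro on compound 3 at the assay limit

The source may hold more compounds than are shown below. What is called first, only, known or untested is meant among the compounds shown, and "the series" means these compounds.

Compound 3 (`CC(C)=CCC[C@@](C)(/C=C/c1ccccc1)/C=C/c1ccc(O)cc1`) offers no number to start from. In an ADME assay on HEK293 cells (Homo sapiens) for cytotoxicity, with a stated time of 72 h (a lower number here means that less compound is needed, a higher number that more compound is needed for the effect), compound 3 gives > 36600 nM as a limit of the assay and not a number. In this assay compound 1 (`C=C[C@@](C)(/C=C/c1ccc(O)c(/C=C/C(=O)OCC)c1)CCC=C(C)C`) gives > 36600 nM as a limit as well. In this assay compound 2 (`C=C[C@@](C)(/C=C/c1ccc(O)c(/C=C/c2ccc(Cl)cc2)c1)CCC=C(C)C`) gives > 36600 nM as a limit too. Among the compounds with values here, the evidence so far is the limit of > 36600 nM in this assay, at which 3 of the 3 values shown sit, and no series member has a measured number.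

Compound 4 (`CC(C)=CCC[C@](C)(/C=C/c1ccc(O)cc1)/C=C/c1cccc(F)c1`) differs from compound 3 by fluoro in place of hydrogen on an aromatic carbon, meta to a large group, which takes phenyl to 3-fluorophenyl (fluoro in place of hydrogen on an aromatic carbon).

Within the data shown here, the only measured step is a step that the two limits leave unreadable from compound 1 to compound 2 and it exchanges other groups, so it gives no size to carry over. No step beyond the scatter is expected in this assay and no direction can be given. The expected step is a step that the limit leaves unreadable from compound 3 to compound 4 and a report of only a limit is the likeliest outcome. For compound 4 the estimated value is 40000 nM with an expected range of 18000 nM to 80000 nM for this estimate.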

Compound 4, half-maximal effective concentration: > 36600 nM
Compound 4: a limit, no number; the forecaster's own chance of this, stated with the estimate: 85%; the middle value lies beyond the limit too.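

No step can be read between compound 3 and compound 4 in this assay because neither compound gives a number, and the fluoro exchange therefore has no readable size: the limit of > 36600 nM in this assay, at which 4 of the 4 values shown sit.

The compounds shown leave open what concentration, if any, gives the half-maximal effect for any series member, and whether 3-fluorophenyl in place of phenyl shifts it.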